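This account rests on a few compounds, and the source may have more. Where it says the series, first, only, none or still open, it means among the compounds named here.

Compound 1, with structure `Cc1nc(NC(=O)NCc2ccccc2)c2nn(-c3ccccc3)cc2n1`, was tested in an assay on CHO cells for displacement of a labelled ligand from adenosine receptor A1 (Homo sapiens), read by scintillation counting, with a stated time of 120 min, tested at 1 uM (a higher number here means more inhibition at the concentration tested (going by the name of the read-out), a lower number less inhibition), and gave 26%. Going by the values given here, its only measured partner is compound 2, with structure `CC(=O)Nc1nc(C)nc2cn(-c3ccccc3)nc12`, which in this assay gave 25%. Compound 1 therefore holds the higher of the two numbers, yet the step of a number 1 percentage points lower from compound 1 to compound 2 (within the scatter) lies within the scatter, so the two compounds cannot be told apart on these data.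

Compound 3, with structure `COc1ccc(-n2cc3nc(C)nc(NC(=O)NCc4ccccc4)c3n2)cc1`, differs from compound 1 by methoxy in place of hydrogen on an aromatic carbon. Among the compounds with values here, no measured step touches this position: the only step on record concerns the carbonyl substituent, not the phenyl ring, so nothing here shows how this assay responds to a change on that ring. With no evidence of a shift, a step of a number 1 percentage points higher from compound 1 to compound 3 (within the scatter) is expected, that is, none beyond the scatter. Compound 3 is estimated to give 27%, with a range from 8% to 50%.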

Compound 3, a percentage reported as inhibition, at one concentration (the size of the read-out at that concentration, not a potency): 8%
Estimate against measurement, compound 3: 19 percentage points above, within the range that was stated.
By their numbers in this assay, from the lowest: compound 3; then compounds 2 and 1 (each within the scatter of the next).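

In this assay the earlier change on the carbonyl carbon could not be told from the scatter, but the phenyl ring is a place where a change can be read: going from phenyl to 4-methoxyphenyl brings a number 18 percentage points lower from compound 1 to compound 3 (beyond the scatter) and gives the first clear separation among these compounds. Methoxy adds only 2 heavy atoms, on an aromatic carbon para to a large group, so even a small addition at this position can lower the inhibition, although this rests on a single pair. Nothing measured here explains the lower number.

On these data alone, it remains open whether the loss belongs to methoxy itself or would follow any group at this place, such as fluorine, methyl or an amine. As far as these compounds go, it is also open whether methoxy would act the same way with methyl on the carbonyl carbon, as in compound 2.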